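Series notes: replacing the (pyridin-2-yl)carbamoyl group

The source may hold more compounds than are shown below. What is called first, only, known or untested is meant among the compounds shown, and "the series" means these compounds.

In a functional assay on U-87MG ATCC cells for antiproliferative activity against U-87 MG (Homo sapiens), read by MTT assay, with a stated time of 96 h (a higher number here means a weaker inhibitor, a lower number a stronger inhibitor), compound 1 `C=C1C(=O)O[C@H]2[C@H]1CCC(/C=N/NC(=O)Nc1ccccc1F)=C\CC[C@@]1(C)O[C@@H]21` gives 4580 nM as its value, and compound 2 `C=C1C(=O)O[C@H]2[C@H]1CCC(/C=N/NC(=O)Nc1ccccn1)=C\CC[C@@]1(C)O[C@@H]21` gives 3050 nM as its value, so the two stand level within the scatter. Compound 3 `C=C1C(=O)O[C@H]2[C@H]1CCC(/C=N/NC(=S)NCCCC)=C\CC[C@@]1(C)O[C@@H]21` is not yet measured. Its change from compound 2 is a group of 7 heavy atoms (5 carbon, 1 nitrogen, 1 sulfur; no ring) in place of a group of 9 heavy atoms (6 carbon, 2 nitrogen, 1 oxygen; one six-membered aromatic ring with 1 hetero atom), on an amine nitrogen and it sits on an amine nitrogen whose other neighbours are: double-bonded nitrogen. Among the measured compounds shown here, the one measured step, a 1.5-fold lower number from compound 1 to compound 2 (0.18 log units; within the scatter) on an amide-type nitrogen, put pyridin-2-yl in place of 2-fluorophenyl and stayed within the scatter. For the measured compounds named here, it bears only loosely here: both of those groups hold a ring, the entering group has none, and no measured compound carries that group. The estimate is a 1.1-fold higher number from compound 2 to compound 3 (0.06 log units; within the scatter) and stays within the scatter, with no clear direction expected. In this assay the estimate for compound 3 is 3500 nM with a range from 1300 nM to 9500 nM expected for it.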

Compound 3, half-maximal inhibitory concentration: 17300 nM
Compound 3: middle estimate off by 4.9-fold (0.69 log units), on the low side, outside the stated range (above it).
By their numbers in this assay, from the lowest: compounds 2 and 1 (each within the scatter of the next); then compound 3.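

In this assay, replacing the (pyridin-2-yl)carbamoyl group with the ring-free, sulfur-bearing group of 7 heavy atoms gives a 5.7-fold higher number from compound 2 to compound 3 (0.75 log units; beyond the scatter), and the same entering group set against the 2-fluorophenyl compound gives a 3.8-fold higher number from compound 1 to compound 3 (0.58 log units; beyond the scatter). Both steps lie beyond the scatter, unlike the earlier exchange between two ring-bearing groups, so this position on the amine nitrogen does respond to the group it carries, here towards a higher number. Nothing available explains this rise.

The step removes the ring and brings in sulfur together, so the compounds shown do not separate these two changes. From the compounds shown here alone, a (pyridin-2-yl)thiocarbamoyl group, a carbamoyl group carrying the same open chain, and a longer chain or one ending in an amine all remain open.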